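The source may report more compounds than this note shows. Statements on the series, on what has been measured and on what is new or still open speak of the compounds shown alone.

Compound 1 `O=C(O)COc1ccncc1-c1ccc2ccccc2c1` gives 16% in an assay on a protein complex for inhibition of CDK8/Cyclin C (Homo sapiens), with a stated time of 1 h, tested at 10 uM; on this read-out lower numbers stand for less inhibition and higher numbers for more inhibition at the one concentration tested (going by the name of the read-out).
Compound 2 `CN(C)C(=O)/C=C/c1ccncc1-c1ccc2ccccc2c1` gives 100% in this assay.
Compound 3 `O=C(/C=C/c1ccncc1-c1ccc2ccccc2c1)NC1CC1` gives 102% in this assay.

Compound 3 holds the highest number of the three in this assay; its nearest neighbour is compound 2, and the gap a number 2 percentage points higher from compound 2 to compound 3 (within the scatter) lies within the scatter, so the two cannot be ordered. The step of a number 86 percentage points higher from compound 1 to compound 3 (beyond the scatter) is large and sets compound 3 far from compound 1.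

Compound 4 `CNC(=O)COc1ccncc1-c1ccc2ccccc2c1` has not been measured. It differs from compound 3 by (methylcarbamoyl)methoxy in place of 2-(cyclopropylcarbamoyl)ethenyl on an aromatic carbon. The change undoes the ethenyl amide and returns to an oxygen-linked chain, so the measured steps that bear on it are a number 86 percentage points higher from compound 1 to compound 3 (beyond the scatter) and a number 84 percentage points higher from compound 1 to compound 2 (beyond the scatter), both large and both going up when the ethenyl amide replaces the carboxymethoxy group. Compound 4 keeps an amide but on the methoxy chain of compound 1, so a large step downward in this assay is expected, though the amide leaves the end point uncertain. Compound 4 is therefore estimated at 30% (range 5% to 70%), a step of a number 72 percentage points lower from compound 3 to compound 4 (beyond the scatter).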

Compound 4, a percentage reported as inhibition, at one concentration (the size of the read-out at that concentration, not a potency): 4%
For compound 4 the middle estimate is 26 percentage points above the measured one, and the stated range ends above it.
By their numbers in this assay, from the lowest: compound 4; then compound 1; then compounds 2 and 3 (each within the scatter of the next).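

On the aromatic carbon opposite the ring nitrogen, (methylcarbamoyl)methoxy in place of 2-(cyclopropylcarbamoyl)ethenyl gives a number 98 percentage points lower from compound 3 to compound 4 (beyond the scatter) in this assay and the same group in place of 2-(dimethylcarbamoyl)ethenyl gives a number 96 percentage points lower from compound 2 to compound 4 (beyond the scatter) here as well. An amide at this position is thus not enough for a high number, and methylamino in place of hydroxy on the carbonyl carbon of the oxygen-linked chain gives only a number 12 percentage points lower from compound 1 to compound 4 (beyond the scatter) and does not approach the two ethenyl amides. Nothing available here gives a reason for these steps.

The compounds shown leave open whether the oxygen or the ethenyl unit decides the outcome, as both change together in these comparisons. A saturated ethyl chain carrying the same amide, or a cyclopropylamide on the methoxy chain, would separate the two.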